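Bromoacrylamide on the aniline nitrogen of the fluorophenyl analogue

A few compounds are considered here, and "the series" means these few. Any claim that something is new, unique, unknown or untested is made for them only; others in the source may bear on it.

Working notes on a small set of anilines and their acylated counterparts, all read in a functional assay on CCRF-CEM cells (Homo sapiens) for inhibition, read by cell counting, with a stated time of 3 days; a lower number here means a stronger inhibitor, a higher number a weaker inhibitor.

Compound 2 `Nc1cccc(-c2cn3nc(-c4ccc(F)cc4)sc3n2)c1` carries a free aniline and a 4-fluorophenyl group on the shared core. In this assay compound 2 gives only a limit, >= 250000 nM, so its position is an edge of the measured range rather than a number; that edge is the limit of >= 250000 nM in this assay, at which 1 of the 3 values shown sits. Within the data shown here, compound 3 `Nc1cccc(-c2cn3nc(Cc4ccccc4)sc3n2)c1` gives 37000 nM, and the only measured step in the set, an at least 6.7-fold lower number from compound 2 to compound 3 (0.82 log units; beyond the scatter), concerns benzyl in place of 4-fluorophenyl on an aromatic carbon, a different site from the one changed below. Compound 1 `C=C(Br)C(=O)Nc1cccc(-c2cn3nc(-c4ccc(OCC)cc4)sc3n2)c1` pairs the acylated nitrogen with a 4-ethoxyphenyl group and in this assay gives 1400 nM.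

Compound 4 `C=C(Br)C(=O)Nc1cccc(-c2cn3nc(-c4ccc(F)cc4)sc3n2)c1` differs from compound 2 by (1-bromoethenyl)carbonyl in place of hydrogen on a nitrogen on an aromatic ring. Among the measured compounds shown here, no measured step covers this change in one place; the one measured step sits at the aryl substituent and does not bear on the nitrogen. What can be read is that compound 1, which carries the acylated nitrogen, sits far inside the measured range, whereas compound 2 sits at the limit. A large downward step is therefore expected for compound 4, an at least 83-fold lower number from compound 2 to compound 4 (1.92 log units; beyond the scatter), and its value in this assay is estimated at 3000 nM, within 500 nM to 30000 nM.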

Compound 4, half-maximal inhibitory concentration: 830 nM
Compound 4: the middle estimate sits 3.6-fold (0.56 log units) above what was measured; low and high end bracket the measured number.
By their numbers in this assay, from the lowest: compounds 4 and 1 (each within the scatter of the next); then compound 3. At a limit, above all of these: compound 2.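

In this assay, the change on the aniline nitrogen now has a measured step of its own, an at least 300-fold lower number from compound 2 to compound 4 (2.47 log units; beyond the scatter), so this position can move the number by a large amount with the 4-fluorophenyl group held fixed. The far end of that step is only an edge, since compound 2 stands at a limit of the assay and not at a number: the limit of >= 250000 nM in this assay, at which 1 of the 4 values shown sits. With (1-bromoethenyl)carbonyl on the nitrogen, exchanging the aryl substituent gives a 1.7-fold lower number from compound 1 to compound 4 (0.23 log units; within the scatter), so fluoro and ethoxy cannot be told apart on this acylated background.

On these data alone, it remains open which part of the acyl group the large step depends on: an acetyl group or a plain propenoyl group without the bromine, on the same nitrogen, would separate the contributions of the carbonyl, the ethenyl and the bromine. Also open, as far as these compounds go, is whether benzyl, as in compound 3, would read like fluoro and ethoxy once the nitrogen is acylated.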